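This account rests on a few compounds, and the source may have more. Where it says the series, first, only, none or still open, it means among the compounds named here.

Within the data shown here, compound 3 `O=C1NN=C(c2ccccc2)/C1=C/Nc1cc(-c2ccccc2)[nH]n1` stands at the low end of the three numbers so far: in a functional assay on MDA-MB-361 cells (Homo sapiens) for antiproliferative activity, read by MTT assay, with a stated time of 72 h (a higher number here means a weaker inhibitor, a lower number a stronger inhibitor), compound 3 gives 42700 nM, while compound 2 `O=C1NN=C(c2ccccc2)/C1=C/Nc1cc[nH]n1` gives 95300 nM and compound 1 `Cc1cc(N/C=C2\C(=O)NN=C2c2ccccc2)n[nH]1` gives 96100 nM. The two steps that install a phenyl group are a 2.3-fold lower number from compound 1 to compound 3 (0.35 log units; beyond the scatter) and a 2.2-fold lower number from compound 2 to compound 3 (0.35 log units; beyond the scatter), whereas a 1.0-fold lower number from compound 1 to compound 2 (0.00 log units; within the scatter).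

Compound 4 `O=C1/C(=C\Nc2cc(-c3ccccc3)[nH]n2)C(c2ccccc2)=NN1c1ccccc1` differs from compound 3 by phenyl in place of hydrogen on an amide-type nitrogen in a ring. Among the measured compounds shown here, no measured step touches this nitrogen; the only phenyl introductions on record sit on the aromatic carbon, and both were modest in size. For the measured compounds named here, a phenyl entering at a second, distinct position therefore has no direct precedent, and the expectation can rest only on the modest size of a 2.2-fold lower number from compound 2 to compound 3 (0.35 log units; beyond the scatter) as a rough guide for what a phenyl has done elsewhere. A step of a 1.2-fold lower number from compound 3 to compound 4 (0.09 log units; within the scatter) is expected, with no firm direction beyond the scatter. The value of compound 4 in this assay is estimated at 35000 nM, within a range from 12000 nM to 100000 nM.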

Compound 4, half-maximal inhibitory concentration: 12200 nM
Compound 4: middle estimate off by 2.9-fold (0.46 log units), on the high side; measured number inside the range.
By their numbers in this assay, from the lowest: compound 4; then compound 3; then compounds 2 and 1 (each within the scatter of the next).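

In this assay, among these compounds, the amide-type nitrogen in a ring, untouched by the earlier compounds, accepts a phenyl in place of hydrogen, and a 3.5-fold lower number from compound 3 to compound 4 (0.54 log units; beyond the scatter) is a modest step beyond the scatter. This makes the nitrogen a second position at which a phenyl lowers the number, and the step is read with the phenyl on the aromatic carbon already in place, so compound 4 carries both groups. No measurement available here bears on why the number falls at this nitrogen.

As far as these compounds go, it remains open whether a phenyl on this nitrogen would give a similar step with hydrogen or methyl on the aromatic carbon in place of phenyl. Also open, from the compounds shown here alone, is how a benzyl group, an amine-bearing chain or a carboxylic acid-bearing chain would compare at the same nitrogen.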